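Replacing methoxy with fluoro in compound 1

A few compounds are considered here, and "the series" means these few. Any claim that something is new, unique, unknown or untested is made for them only; others in the source may bear on it.

Measured in a functional assay on HeLa cells (Homo sapiens) for antiproliferative activity, read by CCK-8 assay, with a stated time of 72 h; on this read-out higher numbers stand for weaker inhibition and lower numbers for stronger inhibition:
Compound 1 `COc1ccc(SCc2ccc(C(=O)Nc3ccccc3N)cc2)cc1` gives 2390 nM
Compound 2 `Nc1ccccc1NC(=O)/C=C/c1ccc(CSc2ccc(F)cc2)cc1` gives "not determined" (no result reported)
Compound 3 `COc1ccc(SCc2ccc(C(=O)Nc3ccccc3N)cc2)cc1OC` gives 3070 nM

Compound 1 and compound 3 lie within the scatter of each other, so they share one place on the numbers, and compound 2 adds no number. Compound 4 `Nc1ccccc1NC(=O)c1ccc(CSc2ccc(F)cc2)cc1` has fluoro in place of methoxy on an aromatic carbon, so 4-methoxyphenyl becomes 4-fluorophenyl (fluoro in place of methoxy on an aromatic carbon). Going by the values given here, only one measured step bears on this: a 1.3-fold higher number from compound 1 to compound 3 (0.11 log units; within the scatter). That step involves no fluoro, so it offers only weak guidance. No step beyond the scatter is expected in this assay. Compound 4 is expected near 2500 nM, with an estimated range from 900 nM to 7000 nM. This expectation means a 1.0-fold higher number from compound 1 to compound 4 (0.02 log units; within the scatter).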

Compound 4, half-maximal inhibitory concentration: 5010 nM
The estimate for compound 4 lay 2.0-fold (0.30 log units) below the measured number; the range from low to high includes it.
By their numbers in this assay, from the lowest: compounds 1, 3 and 4 (each within the scatter of the next, the first and the last beyond it).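

In this assay, going by these compounds alone, a 2.1-fold higher number from compound 1 to compound 4 (0.32 log units; beyond the scatter) is the first change to pass the usual scatter, whereas a 1.3-fold higher number from compound 1 to compound 3 (0.11 log units; within the scatter) did not. The group on this aromatic carbon can therefore shift the number, though only modestly here, and methoxy gives the lower number of the pair. No measurement available here explains the shift.

Going by these compounds, with only methoxy and fluoro compared at this position, the trend across other groups remains open. Chloro, an amine or a carboxylic acid in the same place could show whether the shift continues.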